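Sulfide to sulfone series: chloro for methyl on the benzyl ring

This account rests on a few compounds, and the source may have more. Where it says the series, first, only, none or still open, it means among the compounds named here.

Compound 1 `Cc1ccsc1/C=C(/SCc1ccc(Cl)cc1)C(=O)c1ccc(Cl)cc1` gives 50000 nM in a functional assay on DU-145 cells (Homo sapiens) for inhibition, read by trypan blue exclusion, with a stated time of 96 h (a lower number here means a stronger inhibitor of growth, a higher number a weaker inhibitor of growth), and compound 2 `Cc1ccc(CS/C(=C/c2sccc2C)C(=O)c2ccc(Cl)cc2)cc1` gives 10000 nM. The only difference between them is chloro in place of methyl on an aromatic carbon, which produced a 5.0-fold higher number from compound 2 to compound 1 (0.70 log units; beyond the scatter). Compound 3 `Cc1ccc(CS(=O)(=O)/C(=C/c2cc(C)ccc2C)C(=O)c2ccc(Cl)cc2)cc1` gives 1000 nM in this assay; how its core differs from that of compound 2 is not broken down here. Compound 4 `Cc1ccc(C)c(/C=C(\C(=O)c2ccc(Cl)cc2)S(=O)(=O)Cc2ccc(Cl)cc2)c1` is not yet measured; it differs from compound 3 by chloro in place of methyl on an aromatic carbon, the same change seen between compound 2 and compound 1, at the same place. Among the compounds with values here, the expectation for compound 4 is therefore a weaker inhibitor than compound 3, with an expected step of a 4.0-fold higher number from compound 3 to compound 4 (0.60 log units; beyond the scatter), resting only on the single earlier example a 5.0-fold higher number from compound 2 to compound 1 (0.70 log units; beyond the scatter); the core is different, so the size is uncertain. The estimate for compound 4 in this assay is 4000 nM, between 1000 nM and 15000 nM.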

Compound 4, concentration for 50% growth inhibition: 10000 nM
Estimate against measurement, compound 4: 2.5-fold (0.40 log units) below, within the range that was stated.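

In this assay, chloro in place of methyl, 4-methylbenzyl to 4-chlorobenzyl, gives a 10-fold higher number from compound 3 to compound 4 (1.00 log units; beyond the scatter). The change carries from one core to the other in direction, and the two steps do not differ in size: the same change on two cores in this assay, a 5.0-fold higher number (0.70 log units; beyond the scatter) from compound 2 to compound 1 and a 10-fold higher number (1.00 log units; beyond the scatter) from compound 3 to compound 4, 2.0-fold (0.30 log units) apart, within the scatter of two such steps. This rests on two pairs alone, so it shows agreement on these two cores, not a rule for other cores, and it does not say why the number rises.

Open, going by these compounds, is whether other groups in this place, such as methoxy, fluoro or an amine, would fall on the same scale as methyl and chloro. Also open, on these data alone, is how the step behaves when the 4-chlorophenyl group on the carbonyl is replaced.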